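Amide Side Chain Change in a Vero Cytotoxicity Series

The source may report more compounds than this note shows. Statements on the series, on what has been measured and on what is new or still open speak of the compounds shown alone.

Compound 1 `COc1ccc(C(=O)Nc2cc3nc(C4CCCCC4)[nH]c3cc2N(C)C)cc1` gives > 100 ug/mL in an ADME assay on Vero cells (Chlorocebus sabaeus) for cytotoxicity, read by resazurin assay, with a stated time of 3 days (on this read-out lower numbers stand for stronger inhibition and higher numbers for weaker inhibition), which is a limit of the assay and not a number.
Compound 2 `COc1ccc(C(=O)Nc2cc3nc(C4CCCCC4)[nH]c3cc2N2CCCC2)cc1` gives > 100 ug/mL in this assay, which is likewise a limit.

In this assay compound 1 therefore stands only at a limit, and the step that the two limits leave unreadable from compound 1 to compound 2 cannot be read because both values sit at the limit of > 100 ug/mL in this assay, at which 2 of the 2 values shown sit. Compound 3 `CCCOCC(=O)Nc1cc2nc(C3CCCCC3)[nH]c2cc1N(C)C` differs from compound 1 by propoxymethyl in place of 4-methoxyphenyl on a carbonyl carbon. No measured step bears on this change; the one step shown is unreadable. Compound 3 is thus expected to stay at the limit as well, with the step of a number no higher from compound 1 to compound 3 (the limit leaves the size open) expected to show nothing beyond the scatter. Compound 3 is estimated at 100 ug/mL, within 40 ug/mL to 250 ug/mL.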

Compound 3, half-maximal inhibitory concentration: < 50 ug/mL
Compound 3: no number, only a limit (the forecaster's own chance of this, stated with the estimate: 80%); middle value at least 2.0-fold (0.30 log units) from the limit.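

In this assay compound 3 gives < 50 ug/mL, which is a limit of the assay and not a number. Propoxymethyl in place of 4-methoxyphenyl on a carbonyl carbon gives an at least 2.0-fold lower number from compound 1 to compound 3 (0.30 log units; that floor lies within the scatter). Among the compounds shown here, this change therefore offers a first sign that the group on the carbonyl carbon can bear on the read-out, whereas the step to compound 2 cannot be read.

On these data alone, how far the number falls stays open because compound 3 stands at a limit: the limit of < 50 ug/mL in this assay, at which 1 of the 3 values shown sits. Whether a simple alkyl chain without the oxygen, or an amine, on the carbonyl carbon would give a similar read-out also remains open.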